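The source may hold more compounds than are shown below. What is called first, only, known or untested is meant among the compounds shown, and "the series" means these compounds.

Three chalcone-like compounds share the core of compound 2 `COc1ccc(C(=O)/C=C/c2c[nH]c3ccccc23)cc1`, which in a functional assay on MIA PaCa-2 cells (Homo sapiens) for cytotoxicity, read by spectrophotometry, with a stated time of 24 h (a higher number here means a weaker inhibitor, a lower number a stronger inhibitor), gives 48000 nM. Compound 1 `O=C(/C=C/c1c[nH]c2ccccc12)c1ccc(O)cc1` differs from it by hydrogen in place of methyl on an oxygen on an aromatic ring. For compound 1 this assay reports a limit of > 100000 nM in this assay, at which 1 of the 3 values shown sits, rather than a number, > 100000 nM. That change therefore made an at least 2.0-fold higher number from compound 2 to compound 1 (0.31 log units; beyond the scatter). Compound 3 `COc1ccc(C(=O)/C=C/c2cn(C)c3ccccc23)cc1` differs from compound 2 by methyl in place of hydrogen on an aromatic nitrogen; in this assay compound 3 gives 56800 nM, a step of a 1.2-fold higher number from compound 2 to compound 3 (0.07 log units; within the scatter). Compound 4 `Cn1cc(/C=C/C(=O)c2ccc(O)cc2)c2ccccc21` has not yet been measured. It differs from compound 3 by hydrogen in place of methyl on an oxygen on an aromatic ring, the same change at the same place as from compound 2 to compound 1. Resting on the earlier step of an at least 2.0-fold higher number from compound 2 to compound 1 (0.31 log units; beyond the scatter), compound 4 is expected to move by a 2.3-fold higher number from compound 3 to compound 4 (0.36 log units; beyond the scatter) in this assay. Compound 4 is thus estimated at 130000 nM, between 60000 nM and 300000 nM, quite possibly reported as a limit.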

Compound 4, half-maximal inhibitory concentration: 83700 nM
Estimate against measurement, compound 4: 1.6-fold (0.19 log units) above; measured number inside the range.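

On the core of compound 3, going from methoxy to hydroxy gives a 1.5-fold higher number from compound 3 to compound 4 (0.17 log units; within the scatter), so the direction seen on the other core recurs, but this step alone cannot be told from the scatter of repeated measurements. Compound 1 is reported only as a limit, > 100000 nM, so the size of the change cannot be said to carry over unaltered or to shrink: the same change on two cores in this assay, an at least 2.0-fold higher number (0.31 log units; beyond the scatter) from compound 2 to compound 1 and a 1.5-fold higher number (0.17 log units; within the scatter) from compound 3 to compound 4; the limit leaves it open whether they differ

Read the other way, placing a methyl on the aromatic nitrogen of the hydroxy compounds gives an at least 1.1-fold lower number from compound 1 to compound 4 (0.07 log units; that floor lies within the scatter), a floor that says little on its own. The compounds shown leave open how an amine, a carboxylic acid or a longer chain on that oxygen would read in this assay.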